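A few compounds are considered here, and "the series" means these few. Any claim that something is new, unique, unknown or untested is made for them only; others in the source may bear on it.

Measured so far in an ADME assay on A549 cells (Homo sapiens) for cytotoxicity, read by MTT assay, with a stated time of 72 h; a higher number here means a weaker inhibitor, a lower number a stronger inhibitor:

compound 1 `O=C(NNC(=O)c1ccccc1[N+](=O)[O-])c1ccc(-n2cccc2)cc1`: 205000 nM
compound 2 `O=C(NNC(=O)c1ccccc1Br)c1ccc(-n2cccc2)cc1`: 201000 nM
compound 3 `Brc1ccc(-c2nnc(-c3ccc(-n4cccc4)cc3)o2)cc1`: 264000 nM

Compound 1 and compound 2 share one core; compound 3 is built on a different core, and the difference between the two cores is not broken down here. The values of compound 3 and of compound 1 lie within the scatter of each other, and the same holds for compound 3 and compound 2, so no ordering among the three is claimed.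

Among the compounds with values here, the single counted change within the first pair is nitro in place of bromo on an aromatic carbon. Its effect in this assay is a 1.0-fold higher number from compound 2 to compound 1 (0.01 log units; within the scatter), which is within the scatter.

Compound 4 `O=[N+]([O-])c1ccc(-c2nnc(-c3ccc(-n4cccc4)cc3)o2)cc1` is not yet measured. It follows from compound 3 by nitro in place of bromo on an aromatic carbon. Within the data shown here, this is the same kind of change as the one from compound 2 to compound 1, but not the same: in the first pair the place is ortho to a large group, whereas in compound 4 it is para to a large group, and the cores differ as well.

Among the measured compounds shown here, with only one measured instance of this kind of change to rest on, the expectation for compound 4 is that the step of a 1.0-fold higher number from compound 3 to compound 4 (0.01 log units; within the scatter) is estimated to be about as small as a 1.0-fold higher number from compound 2 to compound 1 (0.01 log units; within the scatter), because that step lay within the scatter. Compound 4 is therefore expected to give about 270000 nM in this assay, with an estimated range from 130000 nM to 560000 nM.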

Compound 4, half-maximal inhibitory concentration: 258000 nM
For compound 4 the middle estimate is 1.0-fold (0.02 log units) above the measured one; low and high end bracket the measured number.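

In this assay, nitro in place of bromo on an aromatic carbon, para to a large group, gives a 1.0-fold lower number from compound 3 to compound 4 (0.01 log units; within the scatter). Set beside the earlier step on the other core, this change shows no difference between the two cores: the same change on two cores in this assay, a 1.0-fold higher number (0.01 log units; within the scatter) from compound 2 to compound 1 and a 1.0-fold lower number (0.01 log units; within the scatter) from compound 3 to compound 4, 1.0-fold (0.02 log units) apart, within the scatter of two such steps

This supports only a narrow statement: on these two cores, exchanging bromo for nitro leaves the number within the scatter, so a step that small can be carried from one core to the other in this series. It does not show that a step beyond the scatter would carry over in the same way, and with just two pairs, which differ in the place of the change on the ring as well as in the core, the influence of place cannot be separated from that of core.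

The compounds shown leave open whether another group in this place, such as an amine, a carboxylic acid or a longer alkyl chain, would move the number beyond the scatter on either core. Also open, as far as these compounds go, is whether the exchange of bromo for nitro stays this small in any read-out other than this assay.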